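A few compounds are considered here, and "the series" means these few. Any claim that something is new, unique, unknown or untested is made for them only; others in the source may bear on it.

Working notes on the series. Compound 1 `C[C@@H]1C(=O)N[C@H](Cc2ccc(F)cc2)C(=O)NCCCc2ccccc2OCCN[C@@H](C2CC2)C(=O)N1C` gives 14 h in an in vivo ADME assay on the whole organism (strain Sprague-Dawley) for metabolic stability, with Rattus norvegicus as the target; on this read-out higher numbers stand for a longer-lived compound and lower numbers for a shorter-lived compound. Compound 2 `CC[C@H](C)[C@@H]1NC[C@@H](C)Oc2ccccc2CCCNC(=O)[C@@H](Cc2ccc(F)cc2)NC(=O)[C@@H](C)N(C)C1=O` gives 44 h in this assay, the higher of the two numbers at hand, with compound 1 the only other point and lying beyond the scatter below it. Compound 3 `C[C@@H]1CN[C@@H](C2CCCCC2)C(=O)N(C)[C@H](C)C(=O)N[C@H](Cc2ccc(F)cc2)C(=O)NCCCc2ccccc2O1` has not been run in this assay. It differs from compound 2 in one place: cyclohexyl in place of sec-butyl on a saturated ring carbon. For the measured compounds named here, no comparable step between measured compounds exists in the set, so the size of the change is uncertain; the expected step of a 1.1-fold lower number from compound 2 to compound 3 (0.04 log units; within the scatter) is small, not beyond the scatter. For compound 3 the estimated half-life in this assay is 40 h, with a range from 15 h to 90 h.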

Compound 3, half-life: 74 h
Compound 3: the middle estimate sits 1.9-fold (0.27 log units) below what was measured; measured number inside the range.
By their numbers in this assay, from the lowest: compound 1; then compounds 2 and 3 (each within the scatter of the next).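

On the saturated ring carbon next to the ring nitrogen, cyclohexyl in place of sec-butyl gives a 1.7-fold higher number from compound 2 to compound 3 (0.23 log units; within the scatter) in this assay on the shared core. The half-life therefore stays within the scatter when a group with no ring gives way to a six-membered carbon ring at this position. Nothing at hand explains this result.

Going by these compounds, it remains open whether a phenyl ring, an amine or a carboxylic acid on this carbon would read the same. On these data alone, a longer open chain at this position also remains untested by these compounds.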